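Working notes: from 2-cyanobenzyl to 3-fluorobenzyl

The source may report more compounds than this note shows. Statements on the series, on what has been measured and on what is new or still open speak of the compounds shown alone.

Compound 1 `COc1cc(OC)c(-c2coc3cc(OCc4ccccc4F)ccc3c2=O)cc1OC` gives 2900 nM
Compound 2 `COc1cc(OC)c(-c2coc3cc(OCc4ccccc4C#N)ccc3c2=O)cc1OC` gives > 10000 nM (a limit, not a number)

In a functional assay on HCT-116 cells (Homo sapiens) for antiproliferative activity, read by MTT assay, with a stated time of 24 h (on this read-out higher numbers stand for weaker inhibition and lower numbers for stronger inhibition), compound 2 has no number, only the limit > 10000 nM and nothing more exact. The next entry, compound 3 `COc1cc(OC)c(-c2coc3cc(OCc4cccc(F)c4)ccc3c2=O)cc1OC`, is still unmeasured. The change is 3-fluorophenyl in place of 2-cyanophenyl on a saturated chain carbon bound to an oxygen on an aromatic ring. For the measured compounds named here, the one measured step that bears on it is an at least 3.4-fold higher number from compound 1 to compound 2 (0.53 log units; beyond the scatter), with cyano in place of fluoro on an aromatic carbon. Going by the values given here, compound 3 gives up the cyano and carries fluoro again, though as 3-fluorophenyl, a form with no measured step of its own. Read in reverse, that step points to a modest or larger move towards stronger inhibition, so the expected step is an at least 2.8-fold lower number from compound 2 to compound 3 (0.45 log units; beyond the scatter) in this assay. For compound 3 the estimated value is 3500 nM, with an expected range of 1200 nM to 9500 nM.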

Compound 3, half-maximal inhibitory concentration: 4920 nM
Estimate against measurement, compound 3: 1.4-fold (0.15 log units) below, within the range that was stated.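

In this assay, changing the 2-fluorophenyl to a 3-fluorophenyl gives a 1.7-fold higher number from compound 1 to compound 3 (0.23 log units; within the scatter), so these two fluorinated benzyl ethers are not separated on this read-out. Taking the 2-cyanophenyl out in favour of 3-fluorophenyl at the same place gives an at least 2.0-fold lower number from compound 2 to compound 3 (0.30 log units; that floor lies within the scatter), which is a floor and not a measured size, and on its own it does not establish a real gain. Compound 2 holds only a limit and not a number, so the true size of this step stays undefined: the limit of > 10000 nM in this assay, at which 1 of the 3 values shown sits.

The compounds shown compare only fluoro and cyano on this ring, at the places named. As far as these compounds go, how an amine or a carboxylic acid on the same ring, or a longer chain in place of the benzyl carbon, would read in this assay remains open.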